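This account rests on a few compounds, and the source may have more. Where it says the series, first, only, none or still open, it means among the compounds named here.

Compound 1 `CC(NC(=O)c1ccc(C(=N)N)cc1)C(C)(C)C(=O)N1CCC(CC(=O)O)CC1` gives 0.883 h
Compound 2 `CC(C)C(NC(=O)c1ccc(C(=N)N)cc1)C(C)(C)C(=O)N1CCC(CC(=O)O)CC1` gives 0.8 h

In an in vivo ADME assay on the whole organism (Cavia porcellus) (a lower number here means that the compound disappears faster, a higher number that the compound lasts longer), compound 2 gives 0.8 h and stands level with compound 1 (0.883 h), so the two cannot be told apart. Next comes compound 3 `CCCCC(NC(=O)c1ccc(C(=N)N)cc1)C(C)(C)C(=O)N1CCC(CC(=O)O)CC1`, which has butyl in place of isopropyl on a saturated chain carbon bound to an amide-type nitrogen and a saturated chain carbon. Among the compounds with values here, the one measured step at this carbon replaced methyl with isopropyl, and it was small: a 1.1-fold lower number from compound 1 to compound 2 (0.04 log units; within the scatter). Within the data shown here, that single step is thin evidence, and no measured compound carries a butyl. Even so, no shift beyond the scatter is expected, and the estimated step is no change at the digits printed from compound 2 to compound 3 (within the scatter) in this comparison. In this assay the estimate for compound 3 is 0.8 h, with an expected range of 0.45 h to 1.4 h on repeated measurement.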

Compound 3, half-life: 1.03 h
Compound 3: the middle estimate sits 1.3-fold (0.11 log units) below what was measured; low and high end bracket the measured number.
By their numbers in this assay, from the lowest: compounds 2, 1 and 3 (each within the scatter of the next).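

In this assay the straight butyl chain of compound 3 replaces the branched isopropyl of compound 2 with a 1.3-fold higher number from compound 2 to compound 3 (0.11 log units; within the scatter), and set against the methyl of compound 1 it gives a 1.2-fold higher number from compound 1 to compound 3 (0.07 log units; within the scatter). Methyl, isopropyl and butyl on this saturated chain carbon therefore cannot be told apart by half-life, so among these three compounds neither the branching nor the length of the chain shows a measurable effect. Nothing available here offers an explanation for this flat result.

The compounds shown leave open whether a group of a different kind on this carbon, such as an amine, a carboxylic acid or a phenyl ring, would shift the half-life beyond the scatter. They also leave open whether a chain longer than butyl would do so.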